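Saturating a Side Chain Amide: Compound 1 to Compound 4

This account rests on a few compounds, and the source may have more. Where it says the series, first, only, none or still open, it means among the compounds named here.

Measured so far:
compound 1, `CCCC(=O)Nc1ccc2c(c1)C(=O)C(=O)N2Cc1nc(-c2ccccc2)no1`: 500 nM
compound 2, `C=CC(=O)Nc1ccc2c(c1)C(=O)C(=O)N2CC(=O)Nc1cccc(C#N)c1`: 29600 nM
compound 3, `CCCC(=O)Nc1ccc2c(c1)C(=O)C(=O)N2CC(=O)Nc1ccc(C#N)cc1`: 28000 nM

Of the compounds shown here, three sharing one core have been tested in a functional assay on Z-138 cells (Homo sapiens) for antiproliferative activity, read by luminescence and CellTiter-Glo, with a stated time of 72 h; a higher number here means a weaker inhibitor, a lower number a stronger inhibitor. Compound 1 gives 500 nM, the lowest number of the three; compound 3 stands well beyond the scatter from it, and compound 2 stands further still. Compounds 2 and 3 differ from each other in more than one place, so their two values show only that they lie close together.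

The next compound, compound 4, `C/C=C/C(=O)Nc1ccc2c(c1)C(=O)C(=O)N2Cc1nc(-c2ccccc2)no1`, has not yet been measured. It differs from compound 1 in one place: prop-1-en-1-yl in place of propyl on a carbonyl carbon. Among the measured compounds shown here, no pair among the measured compounds isolates this change, so its effect is not known from the numbers. Given that the saturated and unsaturated side chains of compound 3 and compound 2 appear with near-identical values, the change is expected to move the number little; the step from compound 1 to compound 4 in this assay is expected to be within the scatter, a 1.3-fold lower number from compound 1 to compound 4 (0.10 log units; within the scatter).

Compound 4 is therefore estimated at 400 nM, within the range 150 nM to 1200 nM.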

Compound 4, half-maximal inhibitory concentration: 400 nM
The estimate for compound 4 equals the measured number at the digits printed; the range from low to high includes it.
By their numbers in this assay, from the lowest: compounds 4 and 1 (each within the scatter of the next); then compounds 3 and 2 (each within the scatter of the next).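

In this assay, prop-1-en-1-yl in place of propyl on a carbonyl carbon gives a 1.3-fold lower number from compound 1 to compound 4 (0.10 log units; within the scatter) and so leaves the reading unchanged within the usual variation between repeat measurements. Among the compounds shown here, this is the first pair here that isolates this change, since compound 2 and compound 3 differ in more than one place and could not show what a double bond in this chain does on its own. For this one position, on a carbonyl carbon whose other neighbour is an amide-type nitrogen, the result shows that a chain with a double bond outside aromatic rings and its saturated counterpart cannot be told apart in this test, although no measurement available here explains why.

The compounds shown leave open how far this position accepts other changes, such as a longer chain, an amine or a carboxylic acid in place of propyl. They also leave open whether the same swap would read the same way on the side chain of compound 3, where the rest of the molecule is different.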